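A few compounds are considered here, and "the series" means these few. Any claim that something is new, unique, unknown or untested is made for them only; others in the source may bear on it.

Values in a functional assay on PC-3 cells (Homo sapiens) for inhibition, read by MTT assay, with a stated time of 48 h; a lower number here means a stronger inhibitor of growth, a higher number a weaker inhibitor of growth:
compound 1 `C#CCN(C)Cc1cccc(NCc2ccc(/C=C/C(=O)NO)cc2)c1`: 850 nM
compound 2 `C#CCN(C)Cc1ccc(NCc2ccc(/C=C/C(=O)NO)cc2)cc1`: 750 nM
compound 3 `C#CCN(C)Cc1cccc(NCc2ccc(C(=O)NO)cc2)c1`: > 10000 nM, which is a limit of the assay and not a number.

Compound 1 and compound 2 are built from the same atoms joined differently; the difference between the two cores is not broken down here. Their values in this assay lie within the scatter of each other, so no order between them is drawn. From compound 1 to compound 3 the change is hydroxycarbamoyl in place of 2-(hydroxycarbamoyl)ethenyl on an aromatic carbon, and it gave an at least 11-fold higher number from compound 1 to compound 3 (1.07 log units; beyond the scatter). The size of that step is bounded only downward, because of the limit of > 10000 nM in this assay, at which 1 of the 3 values shown sits.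

Compound 4 `C#CCN(C)Cc1ccc(NCc2ccc(C(=O)NO)cc2)cc1` is not yet measured in this assay. It differs from compound 2 by hydroxycarbamoyl in place of 2-(hydroxycarbamoyl)ethenyl on an aromatic carbon, the same change at a place described in the same words. The expectation for compound 4 rests on compound 2 with 750 nM and on the measured step of an at least 11-fold higher number from compound 1 to compound 3 (1.07 log units; beyond the scatter) carried over unchanged. For compound 4 the step is expected to be a 16-fold higher number from compound 2 to compound 4 (1.20 log units; beyond the scatter). For compound 4 the estimate is 12000 nM, with a range from 6000 nM to 30000 nM, and a limit rather than a number is considered likely.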

Compound 4, concentration for 50% growth inhibition: > 10000 nM
Compound 4: no number, only a limit; the forecaster's own chance of this, stated with the estimate: 75%; the middle value lies beyond the limit too.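

In this assay compound 4 gives > 10000 nM, which is a limit of the assay and not a number. The replacement of 2-(hydroxycarbamoyl)ethenyl by hydroxycarbamoyl gave an at least 13-fold higher number from compound 2 to compound 4 (1.12 log units; beyond the scatter), so the change carries over to the second core in direction, with a large step beyond the scatter on each core: the same change on two cores in this assay, an at least 11-fold higher number (1.07 log units; beyond the scatter) from compound 1 to compound 3 and an at least 13-fold higher number (1.12 log units; beyond the scatter) from compound 2 to compound 4; the limit leaves it open whether they differ. What is not shown is the true size of either step or whether the change costs the same on both cores, as each step is only a lower bound set by the ceiling of the assay: the limit of > 10000 nM in this assay, at which 2 of the 4 values shown sit.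

The compounds shown leave open whether the step follows from the loss of the double bond or from the shorter chain, which a saturated 2-(hydroxycarbamoyl)ethyl group or a longer chain on the same aromatic carbon could separate. Also open, on these data alone, is how a carboxylic acid in place of the hydroxycarbamoyl end would read on either core.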